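Working notes: amide and pyridinone analogues, step to compound 4

The compounds below may be only part of what the source reports. "The series", "measured", "known", "first", "only" and "open" are said of these compounds alone.

Measured so far:
compound 1, `Cc1nc2ccc(NC(=O)COc3ccc(OC(F)(F)F)cc3)cn2c1C`, in an assay on CHO cells for displacement of a labelled ligand from melanin-concentrating hormone receptor 1 (Rattus norvegicus), read by scintillation counting, with a stated time of 1 h (on this read-out lower numbers stand for stronger inhibition and higher numbers for weaker inhibition), gives 7.8 nM
compound 2, `Cc1c(C2CC2)nc2ccc(NC(=O)COc3ccc(OC(F)(F)F)cc3)cn12`, gives 6.3 nM
compound 3, `Cc1c(C2CC2)nc2ccc(-n3ccc(OCc4ccc(C(C)C)cc4)cc3=O)cn12`, gives 240 nM

Compound 3 stands at the highest number of the three in this assay; compound 1 and compound 2 both give far lower numbers, and the gap from either to compound 3 is beyond the scatter. Among the measured compounds shown here, the only measured single-point step, a 1.2-fold lower number from compound 1 to compound 2 (0.09 log units; within the scatter), concerns the substituent on the shared core and is within the scatter; it says nothing about the group on the saturated chain carbon bound to an oxygen on an aromatic ring, where compound 3 and compound 4 differ.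

Compound 4, `Cc1c(C2CC2)nc2ccc(-n3ccc(OCc4csc(C(F)(F)F)c4)cc3=O)cn12`, carries 5-(trifluoromethyl)thiophen-3-yl in place of 4-isopropylphenyl on a saturated chain carbon bound to an oxygen on an aromatic ring. For the measured compounds named here, no measured pair varies this group, so there is no step on which to base a direction for this assay. The expectation is therefore a step of no particular direction beyond the scatter, a 1.2-fold higher number from compound 3 to compound 4 (0.07 log units; within the scatter), with a wide range to reflect the absence of precedent. For compound 4 the estimate in this assay is 280 nM, expected to fall between 60 nM and 1300 nM.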

Compound 4, half-maximal inhibitory concentration: 15 nM
The estimate for compound 4 lay 19-fold (1.27 log units) above the measured number; the measured number lies below the stated range.
By their numbers in this assay, from the lowest: compounds 2, 1 and 4 (each within the scatter of the next, the first and the last beyond it); then compound 3.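

In this assay, the group on a saturated chain carbon bound to an oxygen on an aromatic ring turns out to be a sensitive point in this series: 5-(trifluoromethyl)thiophen-3-yl in place of 4-isopropylphenyl gives a 16-fold lower number from compound 3 to compound 4 (1.20 log units; beyond the scatter), a large step and the first one beyond the scatter between compounds that differ in one place. The two groups have the same count of heavy atoms, so the step comes with a change in the ring and its substituent, not in that count, and the entering group also counts one hydrogen-bond acceptor where the leaving group counts none. Nothing in the available data explains the size of this step.

As far as these compounds go, with both the ring and its substituent changing in this single pair, it remains open which of the two carries the step, a question that a phenyl ring bearing trifluoromethyl or a thiophene ring bearing isopropyl could settle. Also open, from the compounds shown here alone, is how far this position accepts a different kind of group, such as an amine, a carboxylic acid or a longer chain.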